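Replacing the 4-phenylpiperidin-1-yl group of compound 3

The source may hold more compounds than are shown below. What is called first, only, known or untested is meant among the compounds shown, and "the series" means these compounds.

Measured in a functional assay on HepG2 cells (Homo sapiens) for antiproliferative activity, read by MTT assay, with a stated time of 72 h; on this read-out higher numbers stand for weaker inhibition and lower numbers for stronger inhibition
Compound 1 `COc1cc2c(Nc3ccc(C#N)cc3)ncnc2cc1OCCCN(C)C` gives > 100000 nM as a limit
Compound 2 `COc1cc2c(Nc3ccc(C#N)cc3)ncnc2cc1OCCCN1CCCCC1CCO` gives > 100000 nM as a limit
Compound 3 `COc1cc2c(Nc3ccc(C#N)cc3)ncnc2cc1OCCCN1CCC(c2ccccc2)CC1` gives 4610 nM as a number

Going by the values given here, compound 3 holds the only actual number in this small set, while compound 1 and compound 2 stand at the limit of > 100000 nM in this assay, at which 2 of the 3 values shown sit, and give no number. Compound 4 `CCN1CCN(CCCOc2cc3ncnc(Nc4ccc(C#N)cc4)c3cc2OC)CC1` differs from compound 3 in one place (4-ethylpiperazin-1-yl in place of 4-phenylpiperidin-1-yl on a saturated chain carbon, three bonds along the chain from an oxygen on an aromatic ring) on the chain. Two large steps bear on this (an at least 21-fold lower number from compound 1 to compound 3 (1.33 log units; beyond the scatter) and an at least 21-fold lower number from compound 2 to compound 3 (1.33 log units; beyond the scatter)), and each lies beyond the scatter with 4-phenylpiperidin-1-yl entering. With that group leaving, a large rise is expected in this assay and the estimate is an 8.7-fold higher number from compound 3 to compound 4 (0.94 log units; beyond the scatter) for this change. For compound 4 the expected value is 40000 nM with an estimated range from 10000 nM to 100000 nM and a reading at the limit may well occur.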

Compound 4, half-maximal inhibitory concentration: 9580 nM
Compound 4: middle estimate off by 4.2-fold (0.62 log units), on the high side; measured number outside the range, below it.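

The earlier steps shown here left it unclear whether the gain at this place depended on the phenyl ring of 4-phenylpiperidin-1-yl, but with 4-ethylpiperazin-1-yl, which has no aromatic ring, this assay shows only a 2.1-fold higher number from compound 3 to compound 4 (0.32 log units; beyond the scatter). The new group also stands well clear of the other two amines, with an at least 10-fold lower number from compound 2 to compound 4 (1.01 log units; beyond the scatter) and an at least 10-fold lower number from compound 1 to compound 4 (1.01 log units; beyond the scatter). Both of these steps start from a limit, not a number: the limit of > 100000 nM in this assay, at which 2 of the 4 values shown sit.

The compounds shown leave open how an unsubstituted piperidin-1-yl or a morpholin-4-yl group would read at this place. They also leave open whether the ring or its 4-substituent carries the gain over dimethylamino.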